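The source may report more compounds than this note shows. Statements on the series, on what has been measured and on what is new or still open speak of the compounds shown alone.

Working notes on the series. Compound 1 `COc1cc(/C=C/C(=O)c2cccc(NC(=O)c3cc(Cl)cc(Cl)c3)c2)ccc1O` gives 4.83 ug/mL in a functional assay on B16 cells (Mus musculus) for inhibition; on this read-out lower numbers stand for stronger inhibition and higher numbers for weaker inhibition. Among the compounds with values here, compound 2 `COc1cc(/C=C/C(=O)c2cccc(NC(=O)c3ccco3)c2)ccc1O`, in which the amide carbonyl carries a furan-2-yl, gives 5.46 ug/mL in this assay; of the two numbers so far it is the higher one, though the only step to it, a 1.1-fold higher number from compound 1 to compound 2 (0.05 log units; within the scatter), lies within the scatter, so the two compounds cannot be ordered.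

Compound 3 `COc1cc(/C=C/C(=O)c2cccc(NC(C)=O)c2)ccc1O` has not yet been measured in this assay. Its change from compound 2 is methyl in place of furan-2-yl on a carbonyl carbon. Within the data shown here, the one measured step on this carbonyl carbon, a 1.1-fold higher number from compound 1 to compound 2 (0.05 log units; within the scatter), shows that exchanging one aromatic ring for another there left the number essentially unchanged. Among the measured compounds shown here, no measured step removes the ring altogether, so the step to a methyl is only loosely anchored. The expectation is for a step of about a 1.2-fold higher number from compound 2 to compound 3 (0.08 log units; within the scatter) in this assay, most likely within the scatter or a little towards weaker inhibition. Compound 3 is therefore estimated at 6.5 ug/mL, with a range of 3.5 ug/mL to 13 ug/mL.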

Compound 3, half-maximal inhibitory concentration: 3.62 ug/mL
The estimate for compound 3 lay 1.8-fold (0.25 log units) above the measured number, and the stated range covers the measured number.
By their numbers in this assay, from the lowest: compounds 3, 1 and 2 (each within the scatter of the next).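

The step of a 1.5-fold lower number from compound 2 to compound 3 (0.18 log units; within the scatter) and the step of a 1.3-fold lower number from compound 1 to compound 3 (0.13 log units; within the scatter) both stay within the scatter in this assay, so a methyl, with no ring at all, cannot be told apart from either aromatic ring on this carbonyl carbon. The earlier pair had only exchanged one ring for another; these steps show that, among the three compounds, a ring here is not needed to keep the number at this level. Nothing at hand bears on why the number stays so flat across these groups.

Still open, as far as these compounds go, is whether a longer chain on this carbonyl carbon, or a group carrying an amine or a carboxylic acid, would move the number beyond the scatter. From the compounds shown here alone, all three compounds also keep the amide, so the outcome of a free amino group in place of the acetamido group remains unknown.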